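The source may hold more compounds than are shown below. What is called first, only, known or untested is meant among the compounds shown, and "the series" means these compounds.

Measured in a functional assay on V79 cells (Cricetulus griseus) for cytotoxicity, read by colony formation; on this read-out higher numbers stand for weaker inhibition and lower numbers for stronger inhibition:

- Compound 1 `Nc1c(F)c(N2CCC(N)C2)cc2c1c(=O)c(C(=O)O)cn2C1CC1`: 54 ug/mL
- Compound 2 `Cc1c(F)c(N2CCC(N)C2)cc2c1c(=O)c(C(=O)O)cn2C1CC1`: 14 ug/mL
- Compound 3 `CSc1c(F)c(N2CCC(N)C2)cc2c1c(=O)c(C(=O)O)cn2C1CC1`: 92 ug/mL
- Compound 4 `COc1c(N2CCC(N)C2)c(F)c(N)c2c(=O)c(C(=O)O)cn(C3CC3)c12`: not yet measured

Compound 1 stands in the upper part of this small set. The step of a 1.7-fold higher number from compound 1 to compound 3 (0.23 log units; within the scatter) stays inside the usual scatter, so those two values cannot be told apart. The step of a 3.9-fold lower number from compound 1 to compound 2 (0.59 log units; beyond the scatter) goes beyond the scatter.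

The structural change is methoxy in place of hydrogen on an aromatic carbon. The new methoxy sits ortho to a 3-aminopyrrolidin-1-yl group and para to an amino group, while the rest of compound 1 stays the same.

Among the compounds with values here, no measured step makes this change, since none of them touches that carbon, so they bear on it only indirectly. The largest, a 6.6-fold higher number from compound 2 to compound 3 (0.82 log units; beyond the scatter), shows that one swap on the shared core can move the number beyond the scatter in this assay. The other two steps point in opposite directions, so they suggest no direction for the methoxy. The expectation is therefore no step beyond the scatter, held with wide uncertainty.

The estimated step is a 1.1-fold higher number from compound 1 to compound 4 (0.05 log units; within the scatter). For compound 4 the expected value is 60 ug/mL, with an estimated range from 20 ug/mL to 170 ug/mL.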

Compound 4, half-maximal inhibitory concentration: 100 ug/mL
Estimate against measurement, compound 4: 1.7-fold (0.22 log units) below; the measured number falls inside the stated range.
By their numbers in this assay, from the lowest: compound 2; then compounds 1, 3 and 4 (each within the scatter of the next).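

In this assay, methoxy in place of hydrogen on the aromatic carbon ortho to a 3-aminopyrrolidin-1-yl group and para to an amino group gives a 1.9-fold higher number from compound 1 to compound 4 (0.27 log units; within the scatter), so the two compounds cannot be told apart. Within the data shown here, this is the first reading at this carbon, since the earlier compounds differ from one another only at the carbon that carries the amino group, and it shows that adding methoxy here, with that amino group in place, produces no change that can be read in this cell test. Nothing available explains why the number holds here, and no separate measurement bears on this result.

As far as these compounds go, it remains open whether a group other than methoxy on this carbon, such as ethoxy, chloro or a dimethylamino group, would also leave the number within the scatter. From the compounds shown here alone, it is also open whether methoxy would behave the same way with methyl in place of the amino group, as in compound 2 with its 14 ug/mL, since one result on one background cannot settle that.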